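A few compounds are considered here, and "the series" means these few. Any claim that something is new, unique, unknown or untested is made for them only; others in the source may bear on it.

Compound 1 `O=C1NCc2c1c1c(c3c2c2ccccc2n3CCO)CCc2cc(OC3CCCC3)ccc2-1`: 32%
Compound 2 `O=C1NCc2c1c1c(c3c2c2ccccc2n3CCO)CCc2cc(OCCO)ccc2-1`: 46%

In an assay on isolated protein for inhibition of mitogen-activated protein kinase kinase kinase 11 (Homo sapiens), tested at 1 uM (a higher number here means more inhibition at the concentration tested (going by the name of the read-out), a lower number less inhibition), compound 2 gives 46% and stands highest of the two numbers measured; its nearest neighbour is compound 1, which in this assay gives 32%. For the measured compounds named here, the one measured step, 2-hydroxyethyl in place of cyclopentyl on an oxygen on an aromatic ring, gave a number 14 percentage points higher from compound 1 to compound 2 (beyond the scatter).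

Compound 3 `N#CCCCOc1ccc2c(c1)CCc1c-2c2c(c3c4ccccc4n(CCO)c13)CNC2=O` is not yet measured. It differs from compound 2 by cyanomethyl in place of hydroxy on a saturated chain carbon, two bonds along the chain from an oxygen on an aromatic ring. Going by the values given here, this change sits in the same chain that the measured step altered, but no measured pair exchanges hydroxy for cyanomethyl, so that step bears on it only loosely. With so little to go on, compound 3 is expected to give 38%, within 20% to 58%, a step of a number 8 percentage points lower from compound 2 to compound 3 (within the scatter) that is expected to lie roughly within the scatter.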

Compound 3, a percentage reported as inhibition, at one concentration (the size of the read-out at that concentration, not a potency): 46%
Compound 3: the middle estimate sits 8 percentage points below what was measured, and the stated range covers the measured number.
By their numbers in this assay, from the lowest: compound 1; then compounds 2 and 3 (each within the scatter of the next).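

In this assay, exchanging the hydroxy for cyanomethyl on the saturated chain carbon gives no change at the digits printed from compound 2 to compound 3 (within the scatter). The hydroxy at the end of the chain is therefore not needed to keep the number at this level, even though the count of hydrogen-bond donors in the changed group falls from one to none. Set against the cyclopentyl group, 3-cyanopropyl gives a number 14 percentage points higher from compound 1 to compound 3 (beyond the scatter), so the earlier rise over cyclopentyl is matched by a second open chain with a different end group. No measurement here explains these numbers.

What the compounds shown leave open is how much the end of this chain can vary. An amine or a carboxylic acid at that end, or a longer chain, might hold the number, raise it or lower it.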